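The compounds below may be only part of what the source reports. "The series", "measured", "known", "first", "only" and "open" are said of these compounds alone.

Compound 1, `O=C1NCc2c(NCc3ccccc3[N+](=O)[O-])cccc21`. In an assay for inhibition of Indoleamine 2,3-dioxygenase 1 (Homo sapiens), with stated times of 10 min and 60 min (on this read-out lower numbers stand for stronger inhibition and higher numbers for weaker inhibition), compound 1 gives > 100000 nM, which is a limit of the assay and not a number.
Compound 2, `O=[N+]([O-])c1cccc(CNc2cc(C(F)(F)F)cc3[nH]ncc23)c1`. In this assay compound 2 gives > 100000 nM, again a limit rather than a number.

Among the measured compounds shown here, compound 2 therefore stands at the edge of what this assay can report, the same edge that the limit of > 100000 nM in this assay, at which 2 of the 2 values shown sit, describes, and no step between the two measured compounds can be drawn from such limits. Compound 3, `FC(F)(F)c1cc(NCc2cccc(Br)c2)c2cn[nH]c2c1`, differs from compound 2 by one change, (bromo in place of nitro on an aromatic carbon). For the measured compounds named here, with both measured compounds sitting at the limit, there is no measured step to lean on, so the expectation for this change in this assay is no step beyond the scatter. Compound 3 is accordingly expected to stay at the same edge, with an estimated value of 100000 nM, in a range from 30000 nM to 300000 nM, and the expected step of a number no higher from compound 2 to compound 3 (the limit leaves the size open) is essentially flat.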

Compound 3, half-maximal inhibitory concentration: > 100000 nM
Compound 3 ended at the assay's limit (the forecaster's own chance of this, stated with the estimate: 80%); the middle value sits exactly at the limit.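

No step can be read from compound 2 to compound 3, since each ends at a limit of the assay and not at a number: the limit of > 100000 nM in this assay, at which 3 of the 3 values shown sit.

The compounds shown leave open how bromo and nitro compare in this assay, and whether any close relative of these compounds gives a measurable value there.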